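This account rests on a few compounds, and the source may have more. Where it says the series, first, only, none or still open, it means among the compounds named here.

In a physicochemical assay for solubility, in phosphate buffer, with a stated time of 24 h, at pH 7.4, tested at 100 uM (a lower number here means a less soluble compound, a higher number a more soluble compound), compound 1 `O=C(NCc1ccc(S(=O)(=O)C2CCCOC2)cc1)N1Cc2ccncc2C1` gives 208000 nM and compound 2 `CCC(=O)N1CCC(S(=O)(=O)c2ccc(CNC(=O)N3Cc4ccncc4C3)cc2)CC1` gives 216000 nM. Compound 2 therefore stands level with compound 1, and the two numbers cannot be told apart.

Next in the series is compound 3 `O=C(NCc1ccc(S(=O)(=O)N2CC3(CCOCC3)C2)cc1)N1Cc2ccncc2C1`, which differs from compound 2 at one place, on a sulfonyl sulfur whose other neighbours are: aromatic carbon. The change is a group of 9 heavy atoms (7 carbon, 1 nitrogen, 1 oxygen; one four-membered non-aromatic ring with 1 hetero atom, one six-membered non-aromatic ring with 1 hetero atom) in place of a group of 10 heavy atoms (8 carbon, 1 nitrogen, 1 oxygen; one six-membered non-aromatic ring with 1 hetero atom), on a sulfonyl sulfur. The entering group carries one four-membered non-aromatic ring with 1 hetero atom and one six-membered non-aromatic ring with 1 hetero atom, whereas the leaving 1-propanoylpiperidin-4-yl has only a six-membered one.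

Among the measured compounds shown here, one measured step bears on this, a swap at the same kind of place: a 1.0-fold higher number from compound 1 to compound 2 (0.02 log units; within the scatter). For the measured compounds named here, it is a single step, and no measured compound carries a four-membered ring, so the support is thin. On the evidence of that step, no shift beyond the scatter is expected in this assay. The expected step is a 1.1-fold lower number from compound 2 to compound 3 (0.06 log units; within the scatter). For compound 3 the estimated value is 190000 nM, with an expected range of 110000 nM to 280000 nM.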

Compound 3, solubility: 272000 nM
Compound 3: middle estimate off by 1.4-fold (0.16 log units), on the low side; the measured number falls inside the stated range.
By their numbers in this assay, from the lowest: compounds 1, 2 and 3 (each within the scatter of the next).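

In this assay, the group carrying one four-membered and one six-membered non-aromatic ring, each with 1 hetero atom, replaces 1-propanoylpiperidin-4-yl on the sulfonyl sulfur with a 1.3-fold higher number from compound 2 to compound 3 (0.10 log units; within the scatter), and replaces the smaller six-membered ring group of compound 1 with a 1.3-fold higher number from compound 1 to compound 3 (0.12 log units; within the scatter). Three different groups on this sulfur, including one with a four-membered ring and two without, now give numbers within the scatter of one another, so neither the added ring nor the loss of the double bond outside aromatic rings present in 1-propanoylpiperidin-4-yl moves the read-out beyond the scatter in these compounds. No measurement available here accounts for these small differences.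

The series still shows no step beyond the scatter at this position, so it does not establish which kinds of group, if any, would shift the number. A group with a free amine or a carboxylic acid on the sulfonyl sulfur, or a longer open chain in place of these rings, remains an open test of how far this flat picture extends.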